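Replacing 2,3-dichlorophenyl in an inactive antiproliferative compound

The compounds below may be only part of what the source reports. "The series", "measured", "known", "first", "only" and "open" are said of these compounds alone.

In a functional assay on A549 cells (Homo sapiens) for antiproliferative activity, read by MTT assay, with a stated time of 72 h (on this read-out lower numbers stand for stronger inhibition and higher numbers for weaker inhibition), compound 1 (`O=C(N/N=C/c1cccc(Cl)c1Cl)Nc1ccc(Oc2ccnc3[nH]ccc23)c(F)c1`) gives "not active" (no number reported), so it offers no number as a starting point. Compound 3 (`O=C(N/N=C/c1cccc(Cl)c1Cl)Nc1ccc(Oc2ccnc3[nH]ccc23)cc1`) likewise gives "not active" (no number reported), while compound 2 (`O=C(N/N=C/c1ccccc1)Nc1ccc(Oc2ccnc3[nH]ccc23)cc1`) reads 17200 nM. Compound 4 (`CN(C)CCn1cccc1/C=N/NC(=O)Nc1ccc(Oc2ccnc3[nH]ccc23)c(F)c1`) keeps the core of compound 1 and differs from it by a single change: 1-(2-(dimethylamino)ethyl)-1H-pyrrol-2-yl in place of 2,3-dichlorophenyl on a carbon with a double bond to nitrogen. Among the measured compounds shown here, no measured step shows what such a change does, so the expectation is loose. For the measured compounds named here, a move towards stronger inhibition in this assay is expected, probably a sizeable one, although the only numeric anchor is compound 2 at 17200 nM. The estimated value for compound 4 is 3000 nM, with an expected range of 300 nM to 20000 nM.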

Compound 4, half-maximal inhibitory concentration: "not active" (no number reported)
The entry for compound 4 holds no number; there is nothing to compare the estimate with.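

In this assay compound 1 gives "not active" (no number reported) and compound 4 gives "not active" (no number reported) so no step can be read between them. As far as these compounds go, what the exchange of 2,3-dichlorophenyl for 1-(2-(dimethylamino)ethyl)-1H-pyrrol-2-yl does to inhibition stays open, and no evidence bears on this result.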